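The source may report more compounds than this note shows. Statements on the series, on what has been measured and on what is new or still open speak of the compounds shown alone.

Of the compounds shown here, three on a shared core have been tested in an ADME assay on BaF3 cells (Mus musculus) for antiproliferative activity, read by CCK-8 assay, with a stated time of 72 h; on this read-out lower numbers stand for stronger inhibition of growth and higher numbers for weaker inhibition of growth. Compound 1 (`Cc1cccc(NC(=O)CCSc2ccc3c(/C=C/c4ccccn4)n[nH]c3c2)c1`) gives > 10000 nM, which is a limit of the assay. For the measured compounds named here, compound 2 (`O=C(CCSc1ccc2c(/C=C/c3ccccn3)n[nH]c2c1)Nc1cccc(C(F)(F)F)c1`) gives 2300 nM, the only true number of the three. Compound 3 (`O=C(CCSc1ccc2c(/C=C/c3ccccn3)n[nH]c2c1)Nc1ccc(Cl)c(C(F)(F)F)c1`) gives > 10000 nM, which is also a limit. Compound 3 therefore stands at the limit of > 10000 nM in this assay, at which 2 of the 3 values shown sit.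

Compound 4 (`Cc1ccc(NC(=O)CCSc2ccc3c(/C=C/c4ccccn4)n[nH]c3c2)cc1C(F)(F)F`) has not yet been measured. It carries methyl in place of chloro on an aromatic carbon, ortho to a trifluoromethyl group and para to a large group: methyl in place of chloro on an aromatic carbon.

Going by the values given here, no measured step makes this exact exchange, but two bear on it. Chloro in place of hydrogen at that carbon gave an at least 4.3-fold higher number from compound 2 to compound 3 (0.63 log units; beyond the scatter), so this carbon has already mattered once. Trifluoromethyl in place of methyl elsewhere on the same ring gave an at least 4.3-fold lower number from compound 1 to compound 2 (0.63 log units; beyond the scatter), so a single small change on this ring can move the read-out beyond the scatter. Compound 4 keeps a group on the carbon that is bare in compound 2, so much of the weakening seen in an at least 4.3-fold higher number from compound 2 to compound 3 (0.63 log units; beyond the scatter) is expected to persist.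

A modest move towards a lower number is expected, estimated as an at least 1.6-fold lower number from compound 3 to compound 4 (0.22 log units; that floor lies within the scatter). The estimate for compound 4 is 6000 nM, with an expected range of 2000 nM to 18000 nM.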

Compound 4, concentration for 50% growth inhibition: 530 nM
Compound 4: middle estimate off by 11-fold (1.05 log units), on the high side; measured number below the stated range.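

In this assay, the aromatic carbon para to a large group proves able to carry a substituent, and the outcome depends on which one: methyl there gives a 4.3-fold lower number from compound 2 to compound 4 (0.64 log units; beyond the scatter), whereas chloro at the same carbon gave an at least 4.3-fold higher number from compound 2 to compound 3 (0.63 log units; beyond the scatter). Exchanging one single heavy atom for another at this carbon is thus enough to give an at least 18-fold lower number from compound 3 to compound 4 (1.27 log units; beyond the scatter), and the 4-methyl-3-(trifluoromethyl)phenyl group also gives an at least 18-fold lower number from compound 1 to compound 4 (1.27 log units; beyond the scatter), leaving compound 4 with the lowest number of the four. Compound 1 and compound 3 each stand at a limit, so the step between them cannot be read and the two steps from them to compound 4 are floors rather than sizes: the limit of > 10000 nM in this assay, at which 2 of the 4 values shown sit.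

On these data alone, what remains open is whether an ethyl, a methoxy group, a fluorine or an amine at this carbon would behave like methyl or like chloro. As far as these compounds go, it is also open whether the methyl keeps its effect on a ring without the trifluoromethyl group, and whether the same order of groups holds with a longer chain between the sulfur and the amide carbonyl.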